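The compounds below may be only part of what the source reports. "The series", "measured", "known", "first", "only" and "open" are said of these compounds alone.

In a functional assay on A549 cells (Homo sapiens) for antiproliferative activity, read by MTT assay, with a stated time of 48 h (a higher number here means a weaker inhibitor, a lower number a stronger inhibitor), compound 1 `Fc1ccc(-c2nn(-c3ccccc3)cc2-c2nc3cc(Br)ccc3[nH]2)cc1` gives 5830 nM, compound 3 `Fc1ccc(-c2nn(-c3ccccc3)cc2-c2nc3cc(C(F)(F)F)ccc3[nH]2)cc1` gives 2340 nM and compound 2 `Cc1ccc2[nH]c(-c3cn(-c4ccccc4)nc3-c3ccc(F)cc3)nc2c1` gives 1440 nM. The measured gap a 1.6-fold higher number from compound 2 to compound 3 (0.21 log units; within the scatter) stays within the scatter, while a 4.0-fold lower number from compound 1 to compound 2 (0.61 log units; beyond the scatter) goes beyond it, as does a 2.5-fold lower number from compound 1 to compound 3 (0.40 log units; beyond the scatter). Compound 4 `COc1ccc(-c2nn(-c3ccccc3)cc2-c2nc3cc(C)ccc3[nH]2)cc1` differs from compound 2 by methoxy in place of fluoro on an aromatic carbon. All three measured steps exchange bromo, methyl or trifluoromethyl at another place, so none tests this change directly. They offer only a modest size as a guide and no direction, so no large step is expected. The expected change is a 1.2-fold higher number from compound 2 to compound 4 (0.07 log units; within the scatter). Compound 4 is estimated at 1700 nM, within an expected range of 500 nM to 5500 nM.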

Compound 4, half-maximal inhibitory concentration: 5070 nM
Beside the measured number, compound 4's estimate is 3.0-fold (0.47 log units) below it, within the range that was stated.
By their numbers in this assay, from the lowest: compounds 2 and 3 (each within the scatter of the next); then compounds 4 and 1 (each within the scatter of the next).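

In this assay, the change from 4-fluorophenyl to 4-methoxyphenyl gives a 3.5-fold higher number from compound 2 to compound 4 (0.55 log units; beyond the scatter) and is the only step shown at this position. Going by these compounds alone, the earlier steps all lay at another place, so this is the first sign that the number responds to a change on this ring. No measurement shown accounts for the shift.

With only fluoro and methoxy shown here, it remains open how an amine, a carboxylic acid or a longer chain such as ethoxy would read at this position. Going by these compounds, whether the step holds with bromo or trifluoromethyl at the other place also remains open.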